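The compounds below may be only part of what the source reports. "The series", "measured", "known", "first", "only" and "open" are said of these compounds alone.

Measured so far in a functional assay on HEK293 cells (Homo sapiens) for cytotoxicity; a lower number here means that less compound is tolerated, a higher number that more compound is tolerated:

compound 1, `COc1ccc([C@H]2CC(=O)N(c3ccccc3C(F)(F)F)C2)cc1OC1CCCC1` — compound 1 gives > 10000 nM, which is a limit of the assay and not a number.
compound 2, `COc1ccc([C@H]2CC(=O)N(c3ccc([S+](C)[O-])cc3)C2)cc1OC1CCCC1` — compound 2 gives 7510 nM.
compound 3, `COc1ccc([C@H]2CC(=O)N(c3cccc(NCC4CCOC4)c3)C2)cc1OC1CCCC1` — compound 3 gives > 10000 nM, again a limit of the assay rather than a number.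

Compound 3 therefore stands at the limit, where two of the three values sit: the limit of > 10000 nM in this assay, at which 2 of the 3 values shown sit. Within the data shown here, the one measured step, an at least 1.3-fold lower number from compound 1 to compound 2 (0.12 log units; that floor lies within the scatter), concerns the group on the amide-type nitrogen in the ring and has a floor that lies within the scatter; it does not touch the position changed here.

Compound 4 is `COc1ccc([C@H]2CC(=O)N(c3cccc(NS(=O)(=O)c4c(Br)nn(C)c4Cl)c3)C2)cc1OC1CCCC1`. It differs from compound 3 by (3-bromo-5-chloro-1-methyl-1H-pyrazol-4-yl)sulfonyl in place of (oxolan-3-yl)methyl on a nitrogen on an aromatic ring. Among the measured compounds shown here, no measured step touches this nitrogen on the aromatic ring, so nothing among the measured pairs bears directly on the change.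

With compound 3 at the limit and most of the series sitting there, compound 4 is expected to stay near it: the estimated step is a step that the limit leaves unreadable from compound 3 to compound 4, not beyond the scatter. The estimate for compound 4 is 11000 nM, expected between 4000 nM and 30000 nM, with a fair chance that only a limit is reported.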

Compound 4, half-maximal cytotoxic concentration: > 10000 nM
Compound 4: only a limit was reported (the forecaster's own chance of this, stated with the estimate: 55%); the middle value is on the limit's open side.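

No step from compound 3 to compound 4 can be read in this assay, as both compounds give only a limit: the limit of > 10000 nM in this assay, at which 3 of the 4 values shown sit.

Going by these compounds, whether (3-bromo-5-chloro-1-methyl-1H-pyrazol-4-yl)sulfonyl in place of (oxolan-3-yl)methyl on this nitrogen shifts the tolerated concentration in either direction remains open.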